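Thiosemicarbazone series: furan to pyrrole exchange

This account rests on a few compounds, and the source may have more. Where it says the series, first, only, none or still open, it means among the compounds named here.

Compound 3 `CC1=CC[C@H](C(C)(C)NC(=S)N/N=C/c2ccco2)CC1` gives 10800 nM in a functional assay on OVCAR-3 cells (Homo sapiens) for inhibition, read by sulforhodamine B assay, with a stated time of 48 h (a higher number here means a weaker inhibitor of growth, a lower number a stronger inhibitor of growth), the second highest of the three numbers recorded. Compound 1 `CC1=CC[C@H](C(C)(C)NC(=S)NN)CC1` gives 41900 nM and compound 2 `CC1=CC[C@H](C(C)(C)NC(=S)N/N=C/c2ccc(Cl)cc2)CC1` gives 8600 nM. The step of a 3.9-fold lower number from compound 1 to compound 3 (0.59 log units; beyond the scatter) is the only one beyond the scatter, whereas the step of a 1.3-fold higher number from compound 2 to compound 3 (0.10 log units; within the scatter) lies within it. Compound 4 `CC1=CC[C@H](C(C)(C)NC(=S)N/N=C/c2ccc[nH]2)CC1` carries 1H-pyrrol-2-yl in place of furan-2-yl on a carbon with a double bond to nitrogen. Within the data shown here, the nearest precedent is the exchange of one aromatic group for another from compound 2 to compound 3, which stayed within the scatter, so no shift beyond the scatter is expected in this assay for compound 4. Compound 4 is therefore estimated at 9500 nM, range 4000 nM to 25000 nM. The expected step is a 1.1-fold lower number from compound 3 to compound 4 (0.06 log units; within the scatter).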

Compound 4, concentration for 50% growth inhibition: 33500 nM
The estimate for compound 4 lay 3.5-fold (0.55 log units) below the measured number, outside the stated range (above it).
By their numbers in this assay, from the lowest: compounds 2 and 3 (each within the scatter of the next); then compounds 4 and 1 (each within the scatter of the next).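

At this position, on a carbon with a double bond to nitrogen, the aromatic groups are not interchangeable in this assay: 1H-pyrrol-2-yl in place of furan-2-yl gives a 3.1-fold higher number from compound 3 to compound 4 (0.49 log units; beyond the scatter) and in place of 4-chlorophenyl gives a 3.9-fold higher number from compound 2 to compound 4 (0.59 log units; beyond the scatter). Placing the 1H-pyrrol-2-yl group on the core of compound 1 gives only a 1.3-fold lower number from compound 1 to compound 4 (0.10 log units; within the scatter), so the gain seen with furan-2-yl does not carry over. Nothing available explains this difference. A 1-methylpyrrol-2-yl or thiophen-2-yl group would help show whether the ring hydrogen on nitrogen or the absence of the ring oxygen tracks with this shift.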